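The source may hold more compounds than are shown below. What is called first, only, known or untested is meant among the compounds shown, and "the series" means these compounds.

Of the compounds shown here, three sharing one core have been measured so far in a functional assay (muscle tissue) with Cavia porcellus as the target (a higher number here means that more compound is needed for the effect, a lower number that less compound is needed), for now. Compound 1 `COC(=O)C1=C(C)N=C(C)/C(=C(\O)OC)C1c1ccc(Cl)cc1` gives 8130 nM as its number, compound 2 `COC(=O)C1=C(C)N=C(C)/C(=C(\O)OC)C1c1ccccc1Cl` gives 2.19 nM as its number, and compound 3 `COC(=O)C1=C(C)N=C(C)/C(=C(\O)OC)C1c1cccc([N+](=O)[O-])c1` gives 3.98 nM as its number. Compound 3 thus sits level with compound 2 within the usual scatter, and far from the much higher number of compound 1.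

The next compound, compound 4 `COC(=O)C1=C(C)N=C(C)/C(=C(\O)OC)C1c1cccc(I)c1`, alters compound 3 in one place, with iodo in place of nitro on an aromatic carbon. Within the data shown here, only one measured step exists, a 3700-fold lower number from compound 1 to compound 2 (3.57 log units; beyond the scatter) as a large change, and it moves a chlorine around the aromatic ring. It shows that a group's place can matter greatly, but here the place stays the same and only the group changes. Among the measured compounds shown here, no measured step swaps one group for another in the same place, so the expectation remains loose. The expected change in this assay is a modest one toward a higher number, estimated as a 2.3-fold higher number from compound 3 to compound 4 (0.35 log units; beyond the scatter) and nothing like the large step seen with the chlorine. The estimate for compound 4 is 9 nM with 1.5 nM as the expected low end and 55 nM as the expected high end.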

Compound 4, half-maximal effective concentration: 41.7 nM
Estimate against measurement, compound 4: 4.6-fold (0.67 log units) below; low and high end bracket the measured number.
By their numbers in this assay, from the lowest: compounds 2 and 3 (each within the scatter of the next); then compound 4; then compound 1.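

Holding the place on the aromatic ring fixed and changing only the group still moves the number well beyond the scatter in this assay, with a 10-fold higher number from compound 3 to compound 4 (1.02 log units; beyond the scatter), so the identity of the group matters here as well as its place. Set against the other two rings, the 3-iodophenyl ring gives a 19-fold higher number from compound 2 to compound 4 (1.28 log units; beyond the scatter) and a 190-fold lower number from compound 1 to compound 4 (2.29 log units; beyond the scatter), which puts compound 4 clearly between the 2-chlorophenyl and 4-chlorophenyl compounds. Nothing available explains why iodo and nitro differ at this place.

With only nitro and iodo shown at this place, it remains open how an amine or a carboxylic acid there would compare. On these data alone, it also remains open whether a chlorine on this same ring carbon would fall closer to compound 3 or to compound 4.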